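Methoxy in Place of Ethyl: What Compound 4 Might Need

This account rests on a few compounds, and the source may have more. Where it says the series, first, only, none or still open, it means among the compounds named here.

Compound 1, `CCc1cccc2cc(C(=O)O)cnc12`: 75 mg/kg
Compound 2, `O=c1c(-c2nn[nH]n2)c[nH]c2c(F)ccc(F)c12`: 10 mg/kg
Compound 3, `Fc1ccc2ncc(-c3nn[nH]n3)cc2c1`: 50 mg/kg

In a functional assay on the whole organism (strain Sprague-Dawley) for inhibition, with Rattus norvegicus as the target (on this read-out lower numbers stand for an effect already at smaller amounts and higher numbers for an effect only at larger amounts of compound), compound 1 gives 75 mg/kg, the highest of the three numbers. Compound 3 is nearest with 50 mg/kg, a gap within the scatter, while compound 2 with 10 mg/kg lies beyond it. Compound 4, `COc1cccc2cc(C(=O)O)cnc12`, has not been measured. It differs from compound 1 in one place: methoxy in place of ethyl on an aromatic carbon. Going by the values given here, no step between measured compounds shows this change, so there is nothing to set its size or direction from; the study supports only an expectation of a step that stays within the scatter. Compound 4 is therefore expected to give 60 mg/kg in this assay, in a range from 20 mg/kg to 200 mg/kg, which means an expected step of a 1.3-fold lower number from compound 1 to compound 4 (0.10 log units; within the scatter).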

Compound 4, minimum effective dose: 150 mg/kg
Estimate against measurement, compound 4: 2.5-fold (0.40 log units) below; the range from low to high includes it.
By their numbers in this assay, from the lowest: compound 2; then compounds 3, 1 and 4 (each within the scatter of the next, the first and the last beyond it).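

In this assay, going by these compounds alone, methoxy in place of ethyl on an aromatic carbon gives a 2.0-fold higher number from compound 1 to compound 4 (0.30 log units; within the scatter), the first direct reading of any change at this position. The change brings in a hydrogen-bond acceptor and an oxygen for a carbon, yet the step stays within the scatter, so it sets no firm direction for this swap. No data at hand bear on what lies behind this step. On these data alone, whether an amine, a hydroxyl or a longer chain on this carbon would move the number beyond the scatter remains open. So does whether methoxy in place of ethyl would behave alike on another core.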